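The compounds below may be only part of what the source reports. "The series", "measured", "known", "first", "only" and "open" are said of these compounds alone.

- compound 1 `O=C(/C=C/c1cccs1)c1ccc(OCC2CO2)cc1`: 17200 nM
- compound 2 `O=C(/C=C/c1ccoc1)c1ccc(OCC2CO2)cc1`: 16500 nM
- compound 3 `O=C(/C=C/c1ccsc1)c1ccc(OCC2CO2)cc1`: not yet measured

In a functional assay on MDA-MB-468 cells (Homo sapiens) for inhibition, read by CCK-8 assay and cell counting, with a stated time of 2 days (on this read-out lower numbers stand for stronger inhibition and higher numbers for weaker inhibition), compound 2 and compound 1 cannot be told apart, since their values lie within the scatter of each other. Compound 3 carries thiophen-3-yl in place of furan-3-yl on a double-bonded chain carbon bound to a double-bonded chain carbon. Among the measured compounds shown here, the only measured step that bears on this change, a 1.0-fold lower number from compound 1 to compound 2 (0.02 log units; within the scatter), exchanged thiophen-2-yl for furan-3-yl there and stayed within the scatter. No shift beyond the scatter is therefore expected in this assay. The expected step is a 1.0-fold higher number from compound 2 to compound 3 (0.01 log units; within the scatter). Compound 3 is estimated at 16800 nM, with an expected range of 9500 nM to 30000 nM.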

Compound 3, half-maximal inhibitory concentration: 10800 nM
Beside the measured number, compound 3's estimate is 1.6-fold (0.19 log units) above it; low and high end bracket the measured number.
By their numbers in this assay, from the lowest: compounds 3, 2 and 1 (each within the scatter of the next).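

In this assay the switch to thiophen-3-yl gives a 1.5-fold lower number from compound 2 to compound 3 (0.18 log units; within the scatter) and a 1.6-fold lower number from compound 1 to compound 3 (0.20 log units; within the scatter) and so adds a third ring that cannot be told apart from the other two. At this place, on a double-bonded chain carbon bound to a double-bonded chain carbon, the read-out therefore separates neither oxygen from sulfur in the ring nor thiophen-2-yl from thiophen-3-yl. Nothing available explains the small differences that remain. Still open, from the compounds shown here alone, is whether a phenyl ring, an amine or a carboxylic acid at this place would shift the number beyond the scatter.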